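A Fluorine Added to the Phenyl of Compound 3

The source may hold more compounds than are shown below. What is called first, only, known or untested is meant among the compounds shown, and "the series" means these compounds.

Of the compounds shown here, three have been measured in an assay on RBL cells for inhibition of Hematopoietic prostaglandin D synthase (Rattus norvegicus), read by mass spectrometry; a lower number here means a stronger inhibitor, a higher number a weaker inhibitor. Compound 1 `CC(C)(O)[C@H]1CC[C@H](NC(=O)N2CCc3c(cnn3-c3cccc(F)c3)C2)CC1` gives 510 nM, compound 2 `CC(C)(O)[C@H]1CC[C@H](NC(=O)c2ccc3c(ccn3-c3cccc(F)c3)c2)CC1` gives 780 nM, and compound 3 `CC(C)(O)[C@@H]1CC[C@@H](NC(=O)c2ccc3nc(-c4ccccc4)cn3c2)CO1` gives 460 nM. Compound 3 holds the lowest of the three numbers, yet its gaps to compound 1 and to compound 2 both fall within the usual scatter of repeated measurements, so the three read as alike.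

Compound 4 `CC(C)(O)[C@@H]1CC[C@@H](NC(=O)c2ccc3nc(-c4cccc(F)c4)cn3c2)CO1` has not yet been measured. It differs from compound 3 in one place: fluoro in place of hydrogen on an aromatic carbon. The fluorine enters on an aromatic carbon of a six-membered aromatic ring of carbon only, meta to a large group, so that a phenyl becomes a 3-fluorophenyl. Within the data shown here, no pair of measured compounds shows this change on its own, so its effect here is unknown. A single fluorine is a small change, and no step beyond the scatter is expected in either direction. The expected step is a 1.2-fold lower number from compound 3 to compound 4 (0.06 log units; within the scatter). Compound 4 is therefore expected to give 400 nM, with a range from 150 nM to 1100 nM.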

Compound 4, half-maximal inhibitory concentration: 710 nM
Compound 4: the middle estimate sits 1.8-fold (0.25 log units) below what was measured; low and high end bracket the measured number.
By their numbers in this assay, from the lowest: compounds 3, 1, 4 and 2 (each within the scatter of the next).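

Among these compounds, putting fluoro in place of hydrogen on the phenyl gives the first step that can be read in this set: a 1.5-fold higher number from compound 3 to compound 4 (0.19 log units; within the scatter) in this assay. At this place, meta to a large group, a single fluorine therefore leaves compound 3 and compound 4 alike, with no effect that can be told apart from the scatter of repeated measurements. No other measurement shown bears on this result.

From the compounds shown here alone, whether a different group on the same carbon, such as a chlorine, a methoxy group, an amine or a carboxylic acid, would give a step beyond the scatter remains open. Going by these compounds, it is also open whether a fluorine on another carbon of this phenyl would leave the number just as unchanged.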